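Fluoro for Methoxy: What to Expect from Compound 4

The source may report more compounds than this note shows. Statements on the series, on what has been measured and on what is new or still open speak of the compounds shown alone.

Compound 1 `COc1ccc2cc(C(C)c3nnc4n3N=C(c3ccc(F)cc3)CS4)ccc2c1`: 7000 nM
Compound 2 `COc1ccc(C2=Nn3c(nnc3C(C)c3ccc4cc(OC)ccc4c3)SC2)cc1`: 8500 nM
Compound 3 `COc1ccc(C2=Nn3c(nnc3C(C)c3ccc(CC(C)C)cc3)SC2)cc1`: 3700 nM

All three were tested in a functional assay on Huh-7 cells (Homo sapiens) for inhibition, read by sulforhodamine B assay, with a stated time of 72 h; on this read-out higher numbers stand for weaker inhibition and lower numbers for stronger inhibition. Compound 2 and compound 1 differ in one place only: fluoro in place of methoxy on an aromatic carbon. That change produced a 1.2-fold lower number from compound 2 to compound 1 (0.08 log units; within the scatter). Compound 4, `CC(C)Cc1ccc(C(C)c2nnc3n2N=C(c2ccc(F)cc2)CS3)cc1`, has not yet been measured; it differs from compound 3 by the same change, (fluoro in place of methoxy on an aromatic carbon), with the place described in the same words for both pairs. How the core of compound 3 differs from the core of compound 2 is not broken down here. In this assay compound 3 gives the lowest of the three numbers, though its gap to compound 1 is within the scatter and only its gap to compound 2 lies beyond it. The expected step is a 1.2-fold lower number from compound 3 to compound 4 (0.06 log units; within the scatter), because a 1.2-fold lower number from compound 2 to compound 1 (0.08 log units; within the scatter) stayed within the scatter, and nothing else measured here bears on this change. Compound 4 is therefore estimated at 3200 nM in this assay. The range for compound 4 is expected to run from 1500 nM to 7000 nM.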

Compound 4, half-maximal inhibitory concentration: 7800 nM
For compound 4 the middle estimate is 2.4-fold (0.39 log units) below the measured one, and the stated range ends below it.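

Replacing 4-methoxyphenyl with 4-fluorophenyl gives a 2.1-fold higher number from compound 3 to compound 4 (0.32 log units; beyond the scatter) in this assay, so on this core the change moves towards weaker inhibition, though only modestly. On the other core the same change gave a step within the scatter, yet the two steps cannot be told apart when set side by side: the same change on two cores in this assay, a 1.2-fold lower number (0.08 log units; within the scatter) from compound 2 to compound 1 and a 2.1-fold higher number (0.32 log units; beyond the scatter) from compound 3 to compound 4, 2.6-fold (0.41 log units) apart, within the scatter of two such steps. This means the data do not show that the core alters what the change does, but they do not prove that it carries over unchanged either, since two pairs are a thin basis and one step lies within the scatter while the other lies beyond it.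

The compounds shown compare only methoxy and fluoro at this place, so it remains open how a chloro group, a nitrile or an amine would behave there. On these data alone, it is also open whether the fluoro-for-methoxy change would give a similar step on a core other than these two.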